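Replacing the 2-methoxyethyl arm with isopropyl on the sulfonamide

This account rests on a few compounds, and the source may have more. Where it says the series, first, only, none or still open, it means among the compounds named here.

Compound 1 `COCCN(C)S(=O)(=O)c1ccc(C)c(C#Cc2cc(Cl)ccc2OCC(=O)O)c1` gives 49 mL.min-1.g-1 in an in vitro ADME assay on microsomes from liver (Rattus norvegicus) for metabolic stability, read by LC-MS, tested at 1 uM (on this read-out lower numbers stand for slow clearance and higher numbers for fast clearance), the second highest of three numbers: compound 2 `Cc1ccc(S(=O)(=O)N(C)CC(C)C)cc1C#Cc1cc(Cl)ccc1OCC(=O)O` gives 119 mL.min-1.g-1, a rise of a 2.4-fold higher number from compound 1 to compound 2 (0.39 log units; beyond the scatter), while compound 3 `Cc1ccc(S(C)(=O)=O)cc1C#Cc1cc(Cl)ccc1OCC(=O)O` gives 18 mL.min-1.g-1, a fall of a 2.7-fold lower number from compound 1 to compound 3 (0.43 log units; beyond the scatter). Compound 4 `Cc1ccc(S(=O)(=O)N(C)C(C)C)cc1C#Cc1cc(Cl)ccc1OCC(=O)O` differs from compound 1 by isopropyl in place of 2-methoxyethyl on a sulfonamide nitrogen. Among the compounds with values here, the step that bears on this is the one from compound 1 to compound 2, where isopropyl entered in place of methoxymethyl on a saturated chain carbon bound to the sulfonamide nitrogen and the number rose by a 2.4-fold higher number from compound 1 to compound 2 (0.39 log units; beyond the scatter). A similar but modest rise is therefore expected for compound 4, around a 1.6-fold higher number from compound 1 to compound 4 (0.21 log units; within the scatter), giving an estimated 80 mL.min-1.g-1 with a range from 40 mL.min-1.g-1 to 160 mL.min-1.g-1.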

Compound 4, intrinsic clearance in microsomes: 64 mL.min-1.g-1
Compound 4: the middle estimate sits 1.3-fold (0.10 log units) above what was measured; the measured number falls inside the stated range.
By their numbers in this assay, from the lowest: compound 3; then compounds 1, 4 and 2 (each within the scatter of the next, the first and the last beyond it).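

In this assay, isopropyl on the sulfonamide nitrogen cannot be told apart from 2-methoxyethyl (a 1.3-fold higher number from compound 1 to compound 4 (0.12 log units; within the scatter)) or from isobutyl (a 1.9-fold lower number from compound 2 to compound 4 (0.27 log units; within the scatter)), although compound 1 and compound 2 differ beyond the scatter. The larger difference lies on the sulfonyl sulfur, where isopropyl(methyl)amino takes the place of methyl (a 3.6-fold higher number from compound 3 to compound 4 (0.55 log units; beyond the scatter)). Nothing here accounts for these differences. Left open is whether a hydroxyl or an amine on the chain at this sulfonamide nitrogen, or a shorter ethyl group, would bring the number closer to that of compound 3 (18 mL.min-1.g-1).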